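Inverting Two Ring Stereocentres: From Compound 1 to Compound 4

This account rests on a few compounds, and the source may have more. Where it says the series, first, only, none or still open, it means among the compounds named here.

Measured so far in a functional assay on KB cells (Homo sapiens) for cytotoxicity; a lower number here means a stronger inhibitor, a higher number a weaker inhibitor:
compound 1, `CCCCCCCCCCCCCC[C@H]1N[C@@H](CO)[C@@H]1O`, gives 3.2 ug/mL
compound 2, `CCCCCCCCCCCCCC[C@H]1N[C@H](CO)[C@H]1O`, gives 6 ug/mL
compound 3, `CCCCCCCCCCCCCC[C@H]1N[C@@H](CO)[C@H]1O`, gives only a limit, > 10 ug/mL

Compound 1 holds the lowest of the two numbers shown in this assay, with compound 2 nearest to it; that gap, a 1.9-fold higher number from compound 1 to compound 2 (0.27 log units; within the scatter), sits within the scatter. Compound 3 reaches only the limit of this assay (the limit of > 10 ug/mL in this assay, at which 1 of the 3 values shown sits). The step of an at least 3.1-fold higher number from compound 1 to compound 3 (0.49 log units; beyond the scatter) goes beyond the scatter, so changing a single ring stereocentre (the fact that compounds 1 and 3 differ only in the configuration as drawn) can weaken the compound, whereas the two-centre change (the fact that compounds 1 and 2 differ only in the configuration as drawn) did not.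

Compound 4, `CCCCCCCCCCCCCC[C@@H]1N[C@H](CO)[C@@H]1O`, is not yet measured. It differs from compound 1 as follows: the two compounds have the same atoms and bonds and differ only in configuration as drawn: 2 of 3 stereo elements differ; a stereocentre at a saturated ring carbon is drawn R in compound 1 and S in compound 4; a stereocentre at a saturated ring carbon is drawn S in compound 1 and R in compound 4. Both earlier steps that rearrange ring configuration bear on it: one of two centres left the number within the scatter, one of a single centre pushed it past the limit. Compound 4 is therefore expected to give a number the same as or somewhat higher than that of compound 1, the expected step being a 1.9-fold higher number from compound 1 to compound 4 (0.27 log units; within the scatter). The estimate for compound 4 in this assay is 6 ug/mL, expected to lie between 2.5 ug/mL and 15 ug/mL.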

Compound 4, half-maximal inhibitory concentration: > 10 ug/mL
Compound 4 was reported as a limit; the forecaster's own chance of this, stated with the estimate: 30%; middle value at least 1.6-fold (0.22 log units) from the limit.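

In this assay compound 4 gives > 10 ug/mL, which is a limit of the assay and not a number. The step of an at least 3.1-fold higher number from compound 1 to compound 4 (0.49 log units; beyond the scatter) shows that a two-centre inversion on this ring can weaken the compound, and the loss can be traced to configuration alone because nothing else separates the pair: the fact that compounds 1 and 4 differ only in the configuration as drawn Compound 2 also differs from compound 1 at two ring stereocentres, but at a different pair, so the count of inverted centres does not settle the outcome; which centres are inverted matters, although the step of an at least 1.6-fold higher number from compound 2 to compound 4 (0.22 log units; that floor lies within the scatter) does not clearly separate compound 4 from compound 2.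

As far as these compounds go, compounds 3 and 4 are mirror images, yet the step between them cannot be read because both sit at the limit, so how far either lies past it, and whether they differ at all, stays open. Also open, from the compounds shown here alone, is whether the same dependence on configuration would hold with a shorter chain, or with a carboxylic acid in place of the hydroxymethyl group.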